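Carboxypentyl amide on a dilipidated cysteine scaffold

The source may report more compounds than this note shows. Statements on the series, on what has been measured and on what is new or still open speak of the compounds shown alone.

The series rests on a common lipidated cysteine core that carries a six-carbon chain on the amide nitrogen. Compound 1 `CCCCCCCCCCCC(=O)OC[C@H](CSC[C@@H](N)C(=O)NCCCCCCO)OC(=O)CCCCCCCCCCC` bears a 6-hydroxyhexyl group there and, in an assay on HEK293 cells for agonist activity at Toll-like receptor 2 (Homo sapiens) (a lower number here means that less compound is needed, a higher number that more compound is needed for the effect), compound 1 gives 33 nM. Within the data shown here, compound 2 `CCCCCCCCCCCC(=O)OC[C@H](CSC[C@@H](N)C(=O)NC(C)c1ccccc1)OC(=O)CCCCCCCCCCC` instead carries a 1-phenylethyl group, and in this assay compound 2 gives 9900 nM, the higher of the two numbers measured so far; the step of a 300-fold higher number from compound 1 to compound 2 (2.48 log units; beyond the scatter) shows how far it sits from compound 1.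

Compound 3 `CCCCCCCCCCCC(=O)OC[C@H](CSC[C@@H](N)C(=O)NCCCCCC(=O)O)OC(=O)CCCCCCCCCCC` is the next step: 5-carboxypentyl in place of 1-phenylethyl on an amide-type nitrogen. Among the measured compounds shown here, the only measured step that bears on this change is a 300-fold higher number from compound 1 to compound 2 (2.48 log units; beyond the scatter), where a six-carbon chain ending in a hydroxyl was exchanged for the 1-phenylethyl group. Compound 3 restores a six-carbon chain with a polar terminal group, so the expectation is that most of that step is reversed, and in this assay the estimated step for compound 3 is a 120-fold lower number from compound 2 to compound 3 (2.09 log units; beyond the scatter). In this assay compound 3 is therefore expected near 80 nM, within a range from 15 nM to 600 nM.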

Compound 3, half-maximal effective concentration: 108 nM
The estimate for compound 3 lay 1.4-fold (0.13 log units) below the measured number; low and high end bracket the measured number.
By their numbers in this assay, from the lowest: compound 1; then compound 3; then compound 2.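

In this assay, a chain with no ring, 5-carboxypentyl, brings the number most of the way back from that of the 1-phenylethyl compound, a 92-fold lower number from compound 2 to compound 3 (1.96 log units; beyond the scatter), so the large penalty seen earlier is not tied to the hydroxyl end of compound 1. The end of the chain still registers, though: carboxy in place of hydroxymethyl gives a 3.3-fold higher number from compound 1 to compound 3 (0.51 log units; beyond the scatter), a modest step but one beyond the scatter, which leaves compound 1 with the lowest number of the three. No measurement at hand explains either step.

The compounds shown leave open whether the high number of compound 2 comes from its aromatic ring or from the branching at the carbon on the amide-type nitrogen, since compound 2 differs from the other two in both, and a benzyl group or a plain hexyl chain on that nitrogen would begin to separate these. As far as these compounds go, it also remains open how far the end of the chain can vary, for instance with an amine in place of the carboxy group, or with a longer chain carrying the same hydroxyl.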